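The compounds below may be only part of what the source reports. "The series", "measured", "known", "first", "only" and "open" are said of these compounds alone.

Values in an ADME assay on HEp-2 cells (Homo sapiens) for cytotoxicity; a lower number here means that less compound is tolerated, a higher number that more compound is tolerated:
- compound 1 `CC(C)CCn1c(Cn2c(=O)n(C(C)C)c3ccccc32)nc2cc(CNC3CC3)ccc21`: 17200 nM
- compound 2 `CC(C)CCn1c(Cn2c(=O)n(C(C)C)c3ccccc32)nc2cc(C(C)(C)N)ccc21`: 3270 nM
- compound 3 `CC(C)CCn1c(Cn2c(=O)n(C(C)C)c3ccccc32)nc2c(CCCN)cccc21`: 2340 nM

Compound 2 lies within the scatter of compound 3 and well short of compound 1. The next compound is compound 4 `CC(C)CCn1c(Cn2c(=O)n(C(C)C)c3ccccc32)nc2cc(-c3ncon3)ccc21`, which differs from compound 2 as follows: 1,2,4-oxadiazol-3-yl in place of 1-amino-1-methylethyl on an aromatic carbon. Going by the values given here, the one measured step at this aromatic carbon is a 5.3-fold lower number from compound 1 to compound 2 (0.72 log units; beyond the scatter), an exchange between two groups that both carry an amino nitrogen. Among the compounds with values here, no measured step replaces such a group with a ring like this one, so that step is only a rough guide to size. A modest move to a higher number in this assay is expected. The expected step is a 3.7-fold higher number from compound 2 to compound 4 (0.56 log units; beyond the scatter). The estimate for compound 4 is 12000 nM, with an expected range of 4000 nM to 40000 nM.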

Compound 4, half-maximal cytotoxic concentration: 223000 nM
Compound 4: the middle estimate sits 19-fold (1.27 log units) below what was measured, outside the stated range (above it).
By their numbers in this assay, from the lowest: compounds 3 and 2 (each within the scatter of the next); then compound 1; then compound 4.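

Replacing 1-amino-1-methylethyl with 1,2,4-oxadiazol-3-yl on this aromatic carbon gives a 68-fold higher number from compound 2 to compound 4 (1.83 log units; beyond the scatter) in this assay, and replacing (cyclopropylamino)methyl with the same ring gives a 13-fold higher number from compound 1 to compound 4 (1.11 log units; beyond the scatter) in this assay. This position can therefore move the read-out much further than the exchange between two amino-bearing groups showed, and a group with 0 hydrogen-bond donors stands above both of them. Nothing at hand bears on the cause of this result.

On these data alone, whether the rise belongs to the 1,2,4-oxadiazol-3-yl ring itself or simply follows the loss of the amino nitrogen remains open. A nitrile or a primary amide on this carbon would help separate the two.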